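Thiazole amide acid series: chloro to trifluoromethyl on the aryl

A few compounds are considered here, and "the series" means these few. Any claim that something is new, unique, unknown or untested is made for them only; others in the source may bear on it.

Two compounds of the shared core carry a number in a physicochemical assay for solubility, read by HPLC, in phosphate buffer, measured as thermodynamic solubility, with a stated time of 5 days, at pH 7, tested at 10 mM; on this read-out lower numbers stand for lower solubility and higher numbers for higher solubility. Compound 1 `CC(C)NS(=O)(=O)c1ccc(-c2sc(C(=O)N[C@H]3C[C@H](C(=O)O)C3)nc2CC2CCCCC2)c(C(F)F)c1Cl` gives 11000 nM in this assay. Compound 2 `CC(C)(C)NS(=O)(=O)c1ccc(-c2sc(C(=O)N[C@H]3C[C@H](C(=O)O)C3)nc2CC2CCCCC2)c(Cl)c1` gives 6600 nM in this assay; the two numbers lie within the usual scatter of each other, so nothing separates compound 1 and compound 2 on this read-out. For the measured compounds named here, no step between measured compounds that differ in one place is available, so the change to compound 3 `CC(C)(C)NS(=O)(=O)c1ccc(-c2sc(C(=O)N[C@H]3C[C@H](C(=O)O)C3)nc2CC2CCCCC2)c(C(F)(F)F)c1` has no direct precedent. Compound 3 differs from compound 2 by trifluoromethyl in place of chloro on an aromatic carbon. Going by the values given here, with no measured step to lean on, the expected step from compound 2 to compound 3 in this assay is small, at most a modest move downward and plausibly none beyond the scatter, estimated as a 1.5-fold lower number from compound 2 to compound 3 (0.17 log units; within the scatter). Compound 3 is therefore expected to give 4500 nM in this assay, within a range from 1500 nM to 13000 nM.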

Compound 3, solubility: < 4000 nM
Compound 3: no number, only a limit (the forecaster's own chance of this, stated with the estimate: 5%); at least 1.1-fold (0.05 log units) between middle value and limit.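

In this assay compound 3 gives < 4000 nM, which is a limit of the assay and not a number. The series now holds one step that changes only this aromatic carbon, ortho to a large group, with trifluoromethyl in place of chloro: an at least 1.6-fold lower number from compound 2 to compound 3 (0.21 log units; that floor lies within the scatter), so this change has a floor but no measured size. The result for compound 3 therefore rests on a bound and not on a reading: the limit of < 4000 nM in this assay, at which 1 of the 3 values shown sits.

Going by these compounds, how far the true value of compound 3 lies past its limit stays open, and with it whether the step ends up beyond the scatter. Also open, on these data alone, is how this aromatic carbon responds to a group of another kind, such as a nitrile or an amine, in place of chloro or trifluoromethyl.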